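The source may report more compounds than this note shows. Statements on the series, on what has been measured and on what is new or still open speak of the compounds shown alone.

In a functional assay on KB cells (Homo sapiens) for antiproliferative activity, read by sulforhodamine B assay, with a stated time of 3 days (a lower number here means that less compound is needed, a higher number that more compound is needed for the effect), compound 1 `CCC1=C(O)c2c(oc(-c3ccc(C(C)C)cc3)cc2=O)C(CC)(CC)C1=O` gives 8.13 uM. Compound 2 `CCC1=C(O)c2c(oc(-c3ccc(CBr)cc3)cc2=O)C(CC)(CC)C1=O` gives > 46.5 uM, which is a limit of the assay and not an exact number. Compound 3 `CCC1=C(O)c2c(oc(-c3ccccc3C)cc2=O)C(CC)(CC)C1=O` differs from compound 2 in one place: 2-methylphenyl in place of 4-(bromomethyl)phenyl on an aromatic carbon. In words, 2-methylphenyl stands in place of 4-(bromomethyl)phenyl on an aromatic carbon. Going by the values given here, only one measured step bears on this change: an at least 5.7-fold higher number from compound 1 to compound 2 (0.75 log units; beyond the scatter), which lies beyond the scatter and came with bromomethyl replacing isopropyl. Compound 3 has no bromomethyl group, so its number is expected to fall below the limit of compound 2, probably towards the level of compound 1. This rests on a single step, so the expectation is loose. The expected size of the change is an at least 3.1-fold lower number from compound 2 to compound 3 (0.49 log units; beyond the scatter). For compound 3, the estimated value is 15 uM, with an expected range from 5 uM to 45 uM.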

Compound 3, concentration for half-maximal effect: 40.9 uM
Beside the measured number, compound 3's estimate is 2.7-fold (0.44 log units) below it; low and high end bracket the measured number.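

In this assay, a phenyl ring without bromine still gives a 5.0-fold higher number from compound 1 to compound 3 (0.70 log units; beyond the scatter), so the higher number of compound 2 is not tied to the bromomethyl group alone: 2-methylphenyl also falls short of 4-isopropylphenyl at this position next to the ring oxygen. Compound 2 has only a limit and no exact number: the limit of > 46.5 uM in this assay, at which 1 of the 3 values shown sits. Its comparison with the new compound reads an at least 1.1-fold lower number from compound 2 to compound 3 (0.05 log units; that floor lies within the scatter), a floor that does not show whether replacing 4-(bromomethyl)phenyl with 2-methylphenyl changes the number at all.

The groups 2-methylphenyl and 4-isopropylphenyl differ both in the substituent and in where it sits on the phenyl ring, so these compounds cannot separate those two changes. On these data alone, what an amine or a carboxylic acid on that phenyl ring would do remains open.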